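Trimming the basic side chain from compound 2

The source may hold more compounds than are shown below. What is called first, only, known or untested is meant among the compounds shown, and "the series" means these compounds.

Of the compounds shown here, two have so far been tested in a functional assay on PC-3 cells (Homo sapiens) for antiproliferative activity, read by MTT assay, with a stated time of 72 h; on this read-out lower numbers stand for stronger inhibition and higher numbers for weaker inhibition. Compound 1, `COc1cc2nccc(Oc3ccc(NC(=O)c4ncc(-c5ccc(F)cc5)o4)cc3)c2cc1OC`, gives 21900 nM in this assay. Compound 2, `COc1cc2c(Oc3ccc(NC(=O)c4nnc(-c5ccc(F)cc5)o4)cc3)ccnc2cc1OCCCN1CCC(C)CC1`, gives 3810 nM in this assay, the lowest of the two numbers shown, and its gap to compound 1 lies beyond the usual scatter. The unmeasured compound 3 is `COc1cc2nccc(Oc3ccc(NC(=O)c4nnc(-c5ccc(F)cc5)o4)cc3)c2cc1OC`, in which the long basic chain of compound 2 is cut back to a plain methoxy group: hydrogen in place of 2-(4-methylpiperidin-1-yl)ethyl on a saturated chain carbon bound to an oxygen on an aromatic ring. Within the data shown here, no measured pair shows this change directly, so the size of the step is uncertain. Compound 3 shares with compound 1 the same dimethoxy-bearing core and differs from it only in the five-membered ring of the amide, and compound 1 is the weaker of the two measured compounds. On that basis compound 3 is expected to lose activity, with a step from compound 2 of a 3.1-fold higher number from compound 2 to compound 3 (0.50 log units; beyond the scatter), so that compound 3 is estimated at 12000 nM, expected to fall between 4000 nM and 40000 nM.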

Compound 3, half-maximal inhibitory concentration: > 100000 nM
Compound 3: a limit, no number; the forecaster's own chance of this, stated with the estimate: 10%; middle value at least 8.3-fold (0.92 log units) away from the limit.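

In this assay, compound 3 gives a limit of the assay and not a number: the limit of > 100000 nM in this assay, at which 1 of the 3 values shown sits.

Replacing the 3-(4-methylpiperidin-1-yl)propoxy group with methoxy, with the rest of the molecule unchanged, gives an at least 26-fold higher number from compound 2 to compound 3 (1.41 log units; beyond the scatter), so the measurable activity of compound 2 in this assay depends on that chain. The five-membered ring of the amide also matters when methoxy occupies the chain position: 5-(4-fluorophenyl)-1,3,4-oxadiazol-2-yl in place of 5-(4-fluorophenyl)-1,3-oxazol-2-yl gives an at least 4.5-fold higher number from compound 1 to compound 3 (0.65 log units; beyond the scatter), so the two rings are not interchangeable in this setting.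

The compounds shown cannot tell whether the gain depends on the 4-methylpiperidine ring, the ring nitrogen or simply the chain, a question that a morpholine ring, a dimethylamino group or a plain propoxy chain at the same place would help to separate. Among these compounds, it also remains open whether the 3-(4-methylpiperidin-1-yl)propoxy chain would have a similar effect on a compound carrying the 5-(4-fluorophenyl)-1,3-oxazol-2-yl group, since no such compound appears here.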